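Triazole-linked bicyclic ketones: aryl versus methallyl on the triazole

This account rests on a few compounds, and the source may have more. Where it says the series, first, only, none or still open, it means among the compounds named here.

Measured so far:
compound 1 `O=C1C[C@H](OCc2cn(-c3ccccc3)nn2)[C@H]2CO[C@@H]1O2` — 25200 nM
compound 2 `C=C(C)Cn1cc(CO[C@H]2CC(=O)[C@@H]3OC[C@H]2O3)nn1` — 26700 nM

In a functional assay on MDA-MB-231 cells (Homo sapiens) for cytotoxicity, read by MTT assay, with a stated time of 48 h (on this read-out higher numbers stand for weaker inhibition and lower numbers for stronger inhibition), compound 1 gives 25200 nM and compound 2 gives 26700 nM. Only these two numbers exist in the series, and the step of a 1.1-fold higher number from compound 1 to compound 2 (0.03 log units; within the scatter) lies within the scatter; compound 2 cannot be told apart from compound 1 on this read-out, so nothing in the numbers sets it apart.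

Compound 3 `O=C1C[C@H](OCc2cn(-c3cccc(Cl)c3Cl)nn2)[C@H]2CO[C@@H]1O2` is not yet measured. The change from compound 2 is 2,3-dichlorophenyl in place of 2-methylprop-2-en-1-yl on an aromatic nitrogen. For the measured compounds named here, the one measured step that bears on it is the exchange of the same substituent on the same aromatic nitrogen, a 1.1-fold higher number from compound 1 to compound 2 (0.03 log units; within the scatter), where phenyl and the four-carbon chain gave indistinguishable numbers. That step argues for no step beyond the scatter when a substituted phenyl replaces the chain. Going by the values given here, no measured compound carries chlorine, so the two chlorine atoms add uncertainty without a basis for a direction.

Compound 3 is therefore expected near 22000 nM, range 9000 nM to 55000 nM, which means an estimated step of a 1.2-fold lower number from compound 2 to compound 3 (0.08 log units; within the scatter) that stays within the scatter.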

Compound 3, half-maximal inhibitory concentration: 26000 nM
For compound 3 the middle estimate is 1.2-fold (0.07 log units) below the measured one; measured number inside the range.
By their numbers in this assay, from the lowest: compounds 1, 3 and 2 (each within the scatter of the next).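

In this assay, the first chlorine-bearing compound gives no separation from the plain aryl compound: a 1.0-fold higher number from compound 1 to compound 3 (0.01 log units; within the scatter), so adding two chlorine atoms to the phenyl on the aromatic nitrogen leaves compound 3 indistinguishable from compound 1. The comparison with the chain gives the same reading: a 1.0-fold lower number from compound 2 to compound 3 (0.01 log units; within the scatter), although 2,3-dichlorophenyl has 8 heavy atoms and one six-membered aromatic ring, while 2-methylprop-2-en-1-yl has 4 heavy atoms and no ring. Across compounds 1, 2 and 3, this position therefore takes phenyl, 2,3-dichlorophenyl and 2-methylprop-2-en-1-yl without a difference beyond the scatter, and no data are at hand to explain this.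

From the compounds shown here alone, it remains open whether any group on this nitrogen can separate from these three, for example a phenyl carrying an amine or a carboxylic acid, or a longer chain in place of 2-methylprop-2-en-1-yl. Going by these compounds, the contribution of the shared core, including its carbonyl, also remains open, as all three compounds carry it unaltered.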